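Amide substituent change from compound 2 to compound 3

The source may hold more compounds than are shown below. What is called first, only, known or untested is meant among the compounds shown, and "the series" means these compounds.

Measured so far in a functional assay on KBVIN cells (Homo sapiens) for antiproliferative activity, read by sulforhodamine B assay, with a stated time of 3 days; on this read-out higher numbers stand for weaker inhibition of growth and lower numbers for stronger inhibition of growth:
compound 1 `O=C(Nc1cc(Cl)cc(Cl)c1)c1cccc(Nc2ncc(F)c(Nc3ccc(F)cc3)n2)c1` gives 20700 nM
compound 2 `Cn1ccnc1NC(=O)c1cccc(Nc2ncc(F)c(Nc3ccc(F)cc3)n2)c1` gives 13100 nM

In this assay the values of the two compounds lie within the scatter of each other, so compound 2 cannot be ranked against compound 1.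

Compound 3 `COc1cc(NC(=O)c2cccc(Nc3ncc(F)c(Nc4ccc(F)cc4)n3)c2)cc(OC)c1` is still unmeasured. It carries 3,5-dimethoxyphenyl in place of 1-methyl-1H-imidazol-2-yl on an amide-type nitrogen. Among the measured compounds shown here, one measured step bears on this place (a 1.6-fold lower number from compound 1 to compound 2 (0.20 log units; within the scatter)), where 1-methyl-1H-imidazol-2-yl took the place of 3,5-dichlorophenyl. That step stayed within the scatter. For the measured compounds named here, it is a single step, and no compound with 3,5-dimethoxyphenyl has a value yet, so the data give no ground for expecting a change beyond the scatter. The step expected is small (a 1.1-fold higher number from compound 2 to compound 3 (0.06 log units; within the scatter)), and no clear direction is expected. The expectation rests on compound 2 (13100 nM) and on compound 1 (20700 nM). The estimate for compound 3 is 15000 nM (expected range 6000 nM to 35000 nM).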

Compound 3, concentration for 50% growth inhibition: 12700 nM
Estimate against measurement, compound 3: 1.2-fold (0.07 log units) above; measured number inside the range.
By their numbers in this assay, from the lowest: compounds 3, 2 and 1 (each within the scatter of the next).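

In this assay, the amide-type nitrogen now carries three different groups, and none of the exchanges separates the compounds: 3,5-dimethoxyphenyl in place of 1-methyl-1H-imidazol-2-yl gives (a 1.0-fold lower number from compound 2 to compound 3 (0.01 log units; within the scatter)), and 3,5-dimethoxyphenyl in place of 3,5-dichlorophenyl gives (a 1.6-fold lower number from compound 1 to compound 3 (0.21 log units; within the scatter)). Neither the move from a five-membered aromatic ring with hetero atoms to a six-membered ring of carbon only, nor the larger entering group, nor methoxy in place of chloro on the phenyl ring takes the number beyond the scatter, so compounds 1, 2 and 3 remain unranked at this position. No measurement on hand accounts for this flat reading.

On these data alone, it remains open whether any group on this nitrogen can shift the number beyond the scatter, for instance a piperidine, a carboxylic acid or a longer alkyl chain in place of the aromatic ring. Also open, as far as these compounds go, is whether the flat reading holds when the shared core is changed, since all three compounds carry the same core.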